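Cyclohexyl in place of 4-chlorobenzyl on the amide nitrogen

The compounds below may be only part of what the source reports. "The series", "measured", "known", "first", "only" and "open" are said of these compounds alone.

Compound 1 `C=CC1=C(C(=O)NCc2ccc(Cl)cc2)C(c2ccc(OC)c(OC)c2)OC1` is the anchor of this note. In a functional assay on HeLa cells (Homo sapiens) for cytotoxicity, read by MTT assay, with a stated time of 24 h (a higher number here means a weaker inhibitor, a lower number a stronger inhibitor), compound 1 gives > 100000 nM, which is a limit of the assay and not a number. Compound 2 `C=CC1=C(C(=O)NCc2ccc(Cl)cc2)C(c2ccc(OC)cc2)OC1` gives > 100000 nM in this assay, again a limit. Compound 3 `C=CC1=C(C(=O)NCCC)C(c2ccc(Cl)c(Cl)c2)OC1` gives > 100000 nM, also a limit. Going by the values given here, the single measured step, a step that the two limits leave unreadable from compound 1 to compound 2, is therefore unreadable, and the limit of > 100000 nM in this assay, at which 3 of the 3 values shown sit, is where every value so far sits. Compound 4 `C=CC1=C(C(=O)NC2CCCCC2)C(c2ccc(OC)c(OC)c2)OC1` carries cyclohexyl in place of 4-chlorobenzyl on an amide-type nitrogen. Among the compounds with values here, no measured step touches the amide substituent, so nothing here sets a direction; the only fixed point is compound 1 at its limit. The expected step is a step that the limit leaves unreadable from compound 1 to compound 4, nothing beyond the scatter. Compound 4 is estimated at 150000 nM in this assay, with a range from 40000 nM to 600000 nM.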

Compound 4, half-maximal inhibitory concentration: 5540 nM
Compound 4: middle estimate off by 27-fold (1.43 log units), on the high side, and the stated range ends above it.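

In this assay, going by these compounds alone, the amide nitrogen is the first place where a change can be read: cyclohexyl in place of 4-chlorobenzyl gives an at least 18-fold lower number from compound 1 to compound 4 (1.25 log units; beyond the scatter). Compound 1 stands at a limit of the assay, so this size is only a minimum. Compound 4 is the only compound shown that comes off that limit: the limit of > 100000 nM in this assay, at which 3 of the 4 values shown sit.

On these data alone, whether benzyl without the chlorine or cyclopentyl on the same nitrogen would also come off the limit stays open. So does the effect of replacing methoxy with hydrogen when cyclohexyl is in place.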